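The source may report more compounds than this note shows. Statements on the series, on what has been measured and on what is new or still open speak of the compounds shown alone.

Of the compounds shown here, three have been measured so far in an assay on isolated protein for inhibition of protein kinase C theta type (Homo sapiens), read by TR-FRET, with a stated time of 2 h; a lower number here means a stronger inhibitor, a higher number a weaker inhibitor. Among the measured compounds shown here, compound 1 `N#Cc1cnc(NCc2ccccc2C(F)(F)F)cc1N[C@H]1CC[C@H](O)CC1` gives 4000 nM, and compound 3 `N#Cc1cnc(NCc2ccccc2C(F)(F)F)cc1N[C@H]1C[C@@H](C(N)=O)C1` gives 150 nM; the step of a 27-fold lower number from compound 1 to compound 3 (1.43 log units; beyond the scatter) is the only single-point change among the measured compounds. Compound 2 `CO[C@H]1CC[C@H](Nc2cc(NCc3cnccc3C(F)(F)F)ncc2C#N)CC1`, the starting point here, gives 1100 nM, the second highest number of the three: it is lower than compound 1 and higher than compound 3, both gaps lying beyond the usual scatter.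

Compound 4 `CNC(=O)[C@H]1CC[C@@H](Nc2cc(NCc3cnccc3C(F)(F)F)ncc2C#N)CC1` is reached from compound 2 by the change (4-(methylcarbamoyl)cyclohexyl in place of 4-methoxycyclohexyl on a nitrogen on an aromatic ring). The step from compound 1 to compound 3 bears on this: there an amide replaced a hydroxyl on the group attached to the aromatic nitrogen, and the number fell by a large amount. Compound 4 likewise brings in an amide, this time a methylcarbamoyl group on the six-membered non-aromatic ring, so a lower number is expected, though somewhat less than that large step. The expected step is a 4.4-fold lower number from compound 2 to compound 4 (0.64 log units; beyond the scatter). Compound 4 is therefore estimated at 250 nM, with a likely range from 80 nM to 800 nM.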

Compound 4, half-maximal inhibitory concentration: 27 nM
Compound 4: middle estimate off by 9.3-fold (0.97 log units), on the high side, outside the stated range (below it).
By their numbers in this assay, from the lowest: compound 4; then compound 3; then compound 2; then compound 1.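

On a nitrogen on an aromatic ring, keeping the six-membered non-aromatic ring and exchanging only the group it carries gives a 41-fold lower number from compound 2 to compound 4 (1.61 log units; beyond the scatter) in this assay. In the earlier step, a 27-fold lower number from compound 1 to compound 3 (1.43 log units; beyond the scatter), the ring changed along with the group, so that step could not show what the group does on an unchanged ring; here, 4-(methylcarbamoyl)cyclohexyl replaces 4-methoxycyclohexyl, and a large step appears with the ring kept. Nothing measured here says what lies behind this drop.

The compounds shown leave open whether the methyl on the amide nitrogen matters, and how a plain carbamoyl group, a carboxylic acid or an amine would compare at the same spot on this ring. They also leave open whether the other spatial arrangement of the two ring substituents would give a similar number.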